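The compounds below may be only part of what the source reports. "The series", "measured", "known", "first", "only" and "open" are said of these compounds alone.

Compound 1 `CC(C)(C)c1ccc(CNCCCNS(=O)(=O)c2cc(C(F)(F)F)cc(C(F)(F)F)c2)cc1`: 1400 nM
Compound 2 `O=S(=O)(NCCCNCc1ccc(Cl)c(Cl)c1)c1cc(C(F)(F)F)cc(C(F)(F)F)c1`: 1400 nM
Compound 3 `O=S(=O)(NCCCNCc1ccc(C(F)(F)F)cc1)c1cc(C(F)(F)F)cc(C(F)(F)F)c1`: 1700 nM

In a functional assay on BXPC-3 cells (Homo sapiens) for inhibition, read by MTT assay, with a stated time of 72 h (on this read-out lower numbers stand for stronger inhibition of growth and higher numbers for weaker inhibition of growth), compound 3 gives 1700 nM, the highest of the three numbers, although compound 1, its nearest neighbour, and compound 2, its furthest, both lie within the scatter of it. Compound 4 `O=S(=O)(NCCCNCc1cccc2ccccc12)c1cc(C(F)(F)F)cc(C(F)(F)F)c1` differs from compound 3 by naphthalen-1-yl in place of 4-(trifluoromethyl)phenyl on a saturated chain carbon bound to an amine nitrogen. Two measured steps alter the group at this same place: no change at the digits printed from compound 1 to compound 2 (within the scatter) and a 1.2-fold higher number from compound 2 to compound 3 (0.08 log units; within the scatter). A third, a 1.2-fold higher number from compound 1 to compound 3 (0.08 log units; within the scatter), alters a substituent on the aromatic carbon. None of the three goes beyond the scatter, so another aryl exchange at this place is expected to give a 1.1-fold lower number from compound 3 to compound 4 (0.05 log units; within the scatter), no real shift in this assay. Compound 4 is therefore estimated at 1500 nM, with a range from 600 nM to 4000 nM.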

Compound 4, concentration for 50% growth inhibition: 2700 nM
The estimate for compound 4 lay 1.8-fold (0.26 log units) below the measured number, and the stated range covers the measured number.
By their numbers in this assay, from the lowest: compounds 1, 2, 3 and 4 (each within the scatter of the next).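

Naphthalen-1-yl has two six-membered aromatic rings of carbon only and no fluorine, yet in this assay it stays within the scatter of all three earlier groups (a 1.6-fold higher number from compound 3 to compound 4 (0.20 log units; within the scatter)), (a 1.9-fold higher number from compound 2 to compound 4 (0.29 log units; within the scatter)) and (a 1.9-fold higher number from compound 1 to compound 4 (0.29 log units; within the scatter)). Even this second ring therefore produces no real shift at this place. Nothing measured here offers an explanation for these small steps. As far as these compounds go, whether a cyclohexyl or pyridin-3-yl group here, or a longer chain in the shared core, would move the number beyond the scatter remains open.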